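The source may hold more compounds than are shown below. What is called first, only, known or untested is meant among the compounds shown, and "the series" means these compounds.

In a functional assay on CCRF-CEM cells (Homo sapiens) for cytotoxicity, read by sulforhodamine B assay, with a stated time of 48 h, tested at 0.1 uM (on this read-out lower numbers stand for a stronger effect and higher numbers for a weaker effect at the one concentration tested), compound 1 `COc1cc(-c2cc(/C=C/C(=O)c3ccc(Cl)c(Cl)c3)[nH]n2)cc(OC)c1OC` gives 98% and compound 2 `COc1ccc(C(=O)/C=C/c2cc(-c3cc(OC)c(OC)c(OC)c3)n[nH]2)cc1OC` gives 94%; among these two numbers compound 2 holds the lower one, though the step of a number 4 percentage points lower from compound 1 to compound 2 (within the scatter) lies within the scatter. Compound 3 `COc1cc(-c2cc(/C=C/C(=O)c3ccc(F)c(F)c3)[nH]n2)cc(OC)c1OC` carries a (3,4-difluorophenyl in place of 3,4-dimethoxyphenyl on a carbonyl carbon). For the measured compounds named here, the only step that bears on this change is the exchange of a 3,4-dichlorophenyl for a 3,4-dimethoxyphenyl at the same carbonyl carbon, which left this assay unmoved beyond the scatter, so no step beyond the scatter is expected here either. Compound 3 is therefore estimated to give 96%, between 84% and 104%, a step of a number 2 percentage points higher from compound 2 to compound 3 (within the scatter).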

Compound 3, a percentage reported as activity, at one concentration (the size of the read-out at that concentration, not a potency): 96%
For compound 3 middle estimate and measured number coincide at the digits printed, within the range that was stated.
By their numbers in this assay, from the lowest: compounds 2, 3 and 1 (each within the scatter of the next).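

With the 3,4-difluorophenyl on the carbonyl carbon, this assay shows a number 2 percentage points higher from compound 2 to compound 3 (within the scatter) and a number 2 percentage points lower from compound 1 to compound 3 (within the scatter). A third group at this place therefore joins the 3,4-dichlorophenyl and 3,4-dimethoxyphenyl without separating from either, so the fluorine pair adds no detectable change to the read-out at this single concentration. Nothing available explains this lack of separation. The compounds shown leave open whether a phenyl carrying an amine or a carboxylic acid on this carbonyl carbon would move the number beyond the scatter.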